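The source may hold more compounds than are shown below. What is called first, only, known or untested is meant among the compounds shown, and "the series" means these compounds.

Three compounds share one core. Compound 1 `CCCCCCC#Cc1cc2cn(COCCO)c(=O)nc2o1` and compound 2 `CCCCCCCC#Cc1cc2cn(COCCO)c(=O)nc2o1` carry a triple bond in their chain, while compound 3 `CCCCCCCCCc1cc2cn(COCCO)c(=O)nc2o1` carries a fully saturated nonyl chain. In a functional assay on HEL cells (Homo sapiens), read by microscopy (a higher number here means that more compound is tolerated, a lower number that less compound is tolerated), compound 1 gives only a limit, > 200000 nM. In this assay compound 2 gives 200000 nM. Going by these compounds, compound 3 gives only a limit in this assay, >= 16000 nM, so where it stands above that remains open. Among the measured compounds shown here, the single step between measured compounds, a number no higher from compound 1 to compound 2 (the limit leaves the size open), has a size that cannot be read. Compound 4 `CCCCCc1cc2cn(COCCO)c(=O)nc2o1` differs from compound 3 by hydrogen in place of butyl on a saturated chain carbon, five bonds along the chain from an aromatic carbon. No measured step touches the removal of butyl, and the one step shown leaves its size open, so no shift beyond the scatter is expected. Compound 4 is therefore expected to give 100000 nM, between 16000 nM and 300000 nM. The expected step is a step that the limit leaves unreadable from compound 3 to compound 4.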

Compound 4, minimum cytotoxic concentration: > 400000 nM
Compound 4: only a limit was reported; the forecaster's own chance of this, stated with the estimate: 75%; at least 4.0-fold (0.60 log units) between middle value and limit.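

In this assay compound 3 gives only a limit, >= 16000 nM. Among the compounds shown here, compound 4 also gives only a limit, > 400000 nM, so no step between compound 3 and compound 4 can be read. The compounds shown leave open how large the change is when hydrogen replaces butyl.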